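Nitro in place of chloro in the series

A few compounds are considered here, and "the series" means these few. Any claim that something is new, unique, unknown or untested is made for them only; others in the source may bear on it.

In a functional assay on MDA-MB-231 cells (Homo sapiens) for antiproliferative activity, read by MTT assay, with a stated time of 72 h (on this read-out higher numbers stand for weaker inhibition and lower numbers for stronger inhibition), compound 1 `CC1=CC[C@H]2[C@@H]1CC=C(C)[C@@H](CC[C@H]1[C@]3(C)CC[C@H](O)C(C)(C)O[C@H]3CC[C@@]1(C)O)C2(C)C` reads only as a limit (> 50000 nM). Compound 3 `CC1=CC[C@H]2[C@@H]1CC=C(C)[C@@H](CC[C@H]1[C@]3(C)CC[C@H](OC(=O)c4ccncc4)C(C)(C)O[C@H]3CC[C@@]1(C)O)C2(C)C` gives 19100 nM and compound 2 `CC1=CC[C@H]2[C@H](CC[C@]2(C)O)C(C)(C)[C@@H]1CC[C@H]1[C@]2(C)CC[C@H](OC(=O)c3ccc(Cl)cc3)C(C)(C)O[C@H]2CC[C@@]1(C)O` gives 10300 nM and these two values lie within the scatter of each other. Compound 4 `CC1=CC[C@H]2[C@H](CC[C@]2(C)O)C(C)(C)[C@@H]1CC[C@H]1[C@]2(C)CC[C@H](OC(=O)c3ccc([N+](=O)[O-])cc3)C(C)(C)O[C@H]2CC[C@@]1(C)O` differs from compound 2 by nitro in place of chloro on an aromatic carbon, para to a large group (nitro in place of chloro on an aromatic carbon). For the measured compounds named here, the only measured step (an at least 2.6-fold lower number from compound 1 to compound 3 (0.41 log units; beyond the scatter)) is a different change, (pyridin-4-yl)carbonyl in place of hydrogen on an oxygen, so it gives no size for this exchange. No step beyond the scatter is expected in this assay (a 1.2-fold higher number from compound 2 to compound 4 (0.07 log units; within the scatter)). For compound 4 the estimate is 12000 nM (expected range 5000 nM to 30000 nM).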

Compound 4, half-maximal inhibitory concentration: 8900 nM
Compound 4: the middle estimate sits 1.3-fold (0.13 log units) above what was measured; the range from low to high includes it.
By their numbers in this assay, from the lowest: compounds 4, 2 and 3 (each within the scatter of the next, the first and the last beyond it). At a limit, above all of these: compound 1.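

In this assay, for the compounds shown here, going from 4-chlorophenyl to 4-nitrophenyl gives a 1.2-fold lower number from compound 2 to compound 4 (0.06 log units; within the scatter), the first size for an exchange at this place on the aromatic ring. Nitro and chloro do not separate here, so this position of the ((4-chlorophenyl)carbonyl)oxy ester accepts either group on this read-out. The data offer no measured property that bears on this result.

On these data alone, whether an amine or a carboxylic acid on the same aromatic carbon would separate from chloro and nitro remains open. So does the reading of an unsubstituted phenyl ester on this core.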